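Swapping tert-butyl for phenyl on a shared core

A few compounds are considered here, and "the series" means these few. Any claim that something is new, unique, unknown or untested is made for them only; others in the source may bear on it.

Of the compounds shown here, two built on one shared core have been tested in a functional assay on HeLa cells (Homo sapiens) for cytotoxicity, read by MTT assay, with a stated time of 48 h; a higher number here means a weaker inhibitor, a lower number a stronger inhibitor. Compound 1 `COc1ccc(OC(=O)c2cn(-c3ccccc3)nc2-c2ccncc2)cc1` carries a methoxy group on an outer aromatic ring. In this assay compound 1 gives only a limit, > 100000 nM. Compound 2 `CC(C)(C)c1ccc(OC(=O)c2cn(-c3ccccc3)nc2-c2ccncc2)cc1` carries a tert-butyl group in the same place, and in this assay compound 2 gives 35400 nM. Going by the values given here, the single measured step is an at least 2.8-fold lower number from compound 1 to compound 2 (0.45 log units; beyond the scatter). Among the compounds with values here, compound 2 therefore stands as the only plain number among the values shown, the other being a limit, (the limit of > 100000 nM in this assay, at which 1 of the 2 values shown sits).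

Compound 3 `O=C(Oc1ccc(-c2ccccc2)cc1)c1cn(-c2ccccc2)nc1-c1ccncc1` is the compound still to be measured: phenyl in place of tert-butyl on an aromatic carbon. Within the data shown here, this change again exchanges the group on that aromatic carbon, so the step from compound 1 to compound 2 is the only guide, and that step was at least modest toward a lower number. A modest move toward a lower number is therefore expected for the step from compound 2 to compound 3, a 1.8-fold lower number from compound 2 to compound 3 (0.25 log units; within the scatter). Compound 3 is estimated at 20000 nM, within an expected range from 6000 nM to 70000 nM.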

Compound 3, half-maximal inhibitory concentration: > 100000 nM
Compound 3 gave a limit, no number; the forecaster's own chance of this, stated with the estimate: 15%; middle value at least 5.0-fold (0.69 log units) from the limit.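

Replacing tert-butyl with phenyl on this aromatic carbon gives an at least 2.8-fold higher number from compound 2 to compound 3 (0.45 log units; beyond the scatter) in this assay, so the earlier fall in the number does not continue with every carbon-only group placed here. Phenyl has more heavy atoms than tert-butyl and, like it, has no hydrogen-bond donors or acceptors, yet the two groups do not give the same outcome, which shows that neither a larger group nor the absence of such donors and acceptors is enough on its own to keep a measurable value. Among the three groups shown on this carbon, tert-butyl alone gives a plain number, and the other two compounds end at a limit of the assay: the limit of > 100000 nM in this assay, at which 2 of the 3 values shown sit.

Compound 1 and compound 3 both stand as limits, and the step between them cannot be read, which leaves open how these two compare. Also open, from the compounds shown here alone, is what an isopropyl group, a longer alkyl chain, an amine or a carboxylic acid would give on this same aromatic carbon, and whether any of them would give a lower number than compound 2.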